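Swapping the aryl amine substituent on a pyrimidine urea

The source may hold more compounds than are shown below. What is called first, only, known or untested is meant among the compounds shown, and "the series" means these compounds.

Compound 1 `COc1cc(NC(=O)Nc2cc(Nc3ccc(C(C)(C)C)cc3)ncn2)cc(OC)c1` carries a urea linking a 3,5-dimethoxyphenyl group to the shared core, with a 4-(tert-butyl)phenyl group on the aromatic amine nitrogen. Going by the values given here, in a functional assay on HCC827 cells (Homo sapiens) for inhibition, read by MTT assay, with a stated time of 48 h, tested at 10 uM (a higher number here means more inhibition at the concentration tested (going by the name of the read-out), a lower number less inhibition), compound 1 gives 32.7%, the lowest of the three numbers so far. Compound 2 `CC(C)(C)c1ccc(Nc2cc(NC(=O)Nc3c(Cl)cccc3Cl)ncn2)cc1` gives 42.3%, and the step of a number 9.6 percentage points higher from compound 1 to compound 2 (within the scatter) lies within the scatter. Compound 3 `COc1cc(Nc2cc(NC(=O)Nc3c(Cl)cccc3Cl)ncn2)cc(OC)c1` gives 73.7%, which stands well beyond the scatter above compound 1.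

Compound 4 `COc1cc(NC(=O)Nc2cc(Nc3ccc(OC)c(I)c3)ncn2)cc(OC)c1` differs from compound 1 only in the group on the aromatic amine nitrogen: 3-iodo-4-methoxyphenyl in place of 4-(tert-butyl)phenyl on a nitrogen on an aromatic ring. Among the compounds with values here, no measured step changes this position directly. The only change at this nitrogen shown by the data is between compound 2 and compound 3, where 3,5-dimethoxyphenyl instead of 4-(tert-butyl)phenyl goes with a number beyond the scatter higher, but those two compounds also differ in nothing else, so this hints that the position matters without indicating the direction for a 3-iodo-4-methoxyphenyl group. The step of a number 9.3 percentage points higher from compound 1 to compound 4 (within the scatter) is therefore expected to be modest and uncertain. Compound 4 is estimated at 42%, with a range from 18% to 68%.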

Compound 4, a percentage reported as inhibition, at one concentration (the size of the read-out at that concentration, not a potency): 61.7%
Compound 4: middle estimate off by 19.7 percentage points, on the low side; the measured number falls inside the stated range.
By their numbers in this assay, from the lowest: compounds 1 and 2 (each within the scatter of the next); then compound 4; then compound 3.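

In this assay, changing the group on a nitrogen on an aromatic ring, with the 3,5-dimethoxyphenyl urea side held fixed, gives a clear result: 3-iodo-4-methoxyphenyl in place of 4-(tert-butyl)phenyl goes with a number 29 percentage points higher from compound 1 to compound 4 (beyond the scatter). This shows directly that this position can shift the read-out on its own, and that, of these two groups, the one carrying iodine and methoxy goes with more inhibition. Nothing at hand explains the rise.

On these data alone, it remains open whether the iodine, the methoxy group or the two together account for the step, which a plain 3-iodophenyl or 4-methoxyphenyl group at this nitrogen could help separate. As far as these compounds go, it is also open whether 3-iodo-4-methoxyphenyl would give a similar step with 2,6-dichlorophenyl on the urea.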